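From 4-chlorophenyl to cyclopropylamino on a shared core

The source may hold more compounds than are shown below. What is called first, only, known or untested is meant among the compounds shown, and "the series" means these compounds.

Values in an ADME assay on L1210/0 cells (Mus musculus) for cytotoxicity, with a stated time of 48 h; on this read-out higher numbers stand for weaker inhibition and lower numbers for stronger inhibition:
- compound 1 `OC[C@H]1C[C@@H](Cn2cnc3c(-c4ccc(Cl)cc4)ncnc32)c2ccccc21`: 8440 nM
- compound 2 `O=C1O/C(=C\Cn2cc(C(F)(F)F)c(=O)[nH]c2=O)C(OCc2ccccc2)=C1OCc1ccccc1`: 2000 nM
- compound 3 `CC1=C(C)C(=O)C(c2cn([C@H]3C[C@H](O)[C@@H](CO)O3)c(=O)[nH]c2=O)=C(C)C1=O`: 174000 nM

Among these three, compound 1 holds the second highest number at 8440 nM. Compound 2 lies lower at 2000 nM and compound 3 lies higher at 174000 nM, both beyond the usual scatter from compound 1. The next compound, compound 4 `OC[C@H]1C[C@@H](Cn2cnc3c(NC4CC4)ncnc32)c2ccccc21`, keeps the core of compound 1 but carries cyclopropylamino in place of 4-chlorophenyl on an aromatic carbon. For the measured compounds named here, no two measured compounds differ in one place, so this assay offers no direct guide to this change. A rise beyond the scatter, toward weaker inhibition, is expected, with an estimated 3.6-fold higher number from compound 1 to compound 4 (0.55 log units; beyond the scatter). Compound 4 is expected at 30000 nM, within an estimated range of 8000 nM to 120000 nM.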

Compound 4, half-maximal inhibitory concentration: > 200000 nM
Compound 4 gave a limit, no number (the forecaster's own chance of this, stated with the estimate: 25%); middle value at least 6.6-fold (0.82 log units) from the limit.
By their numbers in this assay, from the lowest: compound 2; then compound 1; then compound 3. At a limit, above all of these: compound 4.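

For the compounds shown here, this is the first single-place step in this assay, and it shows that the aromatic carbon of compound 1 is sensitive to the group it carries. Replacing 4-chlorophenyl with cyclopropylamino gives an at least 23-fold higher number from compound 1 to compound 4 (1.37 log units; beyond the scatter), a large shift toward weaker inhibition. The value for compound 4 is a limit, not a number: the limit of > 200000 nM in this assay, at which 1 of the 4 values shown sits.

The compounds shown leave open whether the step follows the loss of the chlorine, the loss of the aromatic ring or the arrival of the amine nitrogen. An unsubstituted phenyl or an anilino group at this carbon would bear on that question.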